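Methoxy in place of chloro: compound 1 to compound 4

The source may hold more compounds than are shown below. What is called first, only, known or untested is meant among the compounds shown, and "the series" means these compounds.

Compound 1 `CC(c1ccc(-c2ccccc2)c(F)c1)c1nnc2n1N=C(c1ccc(Cl)cc1)CS2` gives 6700 nM in a functional assay on HepG2 cells (Homo sapiens) for inhibition, read by sulforhodamine B assay, with a stated time of 72 h (a lower number here means a stronger inhibitor, a higher number a weaker inhibitor), the second highest of the three numbers shown. Its nearest neighbour is compound 3 `CC(C)Cc1ccc(C(C)c2nnc3n2N=C(c2ccc(Br)cc2)CS3)cc1` with 6400 nM, and the furthest is compound 2 `CC(C)Cc1ccc(C(C)c2nnc3n2N=C(c2ccc(OC(F)(F)F)cc2)CS3)cc1` with 9700 nM, both within the scatter of compound 1. Compound 4 `COc1ccc(C2=Nn3c(nnc3C(C)c3ccc(-c4ccccc4)c(F)c3)SC2)cc1` differs from compound 1 in one place: methoxy in place of chloro on an aromatic carbon. For the measured compounds named here, the only measured step that touches the same position on that ring is a 1.5-fold lower number from compound 2 to compound 3 (0.18 log units; within the scatter), and it stayed within the scatter, so no step beyond the scatter is expected in this assay for compound 4. Compound 4 is therefore estimated at 7500 nM, within a range of 3500 nM to 16000 nM, an expected step of a 1.1-fold higher number from compound 1 to compound 4 (0.05 log units; within the scatter) that remains within the scatter.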

Compound 4, half-maximal inhibitory concentration: 4200 nM
Estimate against measurement, compound 4: 1.8-fold (0.25 log units) above; measured number inside the range.
By their numbers in this assay, from the lowest: compounds 4, 3, 1 and 2 (each within the scatter of the next, the first and the last beyond it).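

In this assay, the change from 4-chlorophenyl to 4-methoxyphenyl gives a 1.6-fold lower number from compound 1 to compound 4 (0.20 log units; within the scatter). The earlier step at this position, para to a large group, came from compounds carrying a different group on the other side of the shared core, so compound 4 extends the evidence to the side chain of compound 1. There, too, replacing the group on this ring leaves the number within the scatter. Nothing shown here gives a reason for this result.

The compounds shown leave open whether an amine or a carboxylic acid at this position would move the number beyond the scatter.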